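A few compounds are considered here, and "the series" means these few. Any claim that something is new, unique, unknown or untested is made for them only; others in the source may bear on it.

Compound 2, whose structure is `Clc1ccc(/C=N/c2sc3c(c2-c2nc4ccccc4s2)CCCC3)cc1`, holds the higher of the two numbers recorded here in an ADME assay on HepG2 cells (Homo sapiens) for cytotoxicity, read by MTT assay, with a stated time of 72 h; on this read-out higher numbers stand for lower toxicity in this test and lower numbers for higher toxicity in this test. In this assay compound 2 gives 397 ug/mL, while compound 1, with the structure `Nc1sc2c(c1-c1nc3ccccc3s1)CCCC2`, gives 163 ug/mL. Among the compounds with values here, the one measured step, a 2.4-fold higher number from compound 1 to compound 2 (0.39 log units; beyond the scatter), came from building the whole chlorophenyl-bearing imine onto the amino nitrogen of compound 1.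

Compound 3, whose structure is `O=[N+]([O-])c1ccccc1/C=N/c1sc2c(c1-c1nc3ccccc3s1)CCCC2`, keeps that imine and changes only the aryl group on it: 2-nitrophenyl in place of 4-chlorophenyl on a carbon with a double bond to nitrogen. Within the data shown here, no measured step covers a swap of this kind; the recorded step from compound 1 to compound 2 tells only that attaching the aryl imine moved the number modestly upward, and nothing about trading one aryl group for another while the imine stays in place. With no guide for this change, the expectation for compound 3 is a step no larger than the scatter, estimated as a 1.2-fold lower number from compound 2 to compound 3 (0.08 log units; within the scatter), in either direction. Compound 3 is therefore expected to give about 330 ug/mL in this assay, with a likely range from 140 ug/mL to 800 ug/mL.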

Compound 3, half-maximal cytotoxic concentration: 393 ug/mL
Estimate against measurement, compound 3: 1.2-fold (0.08 log units) below, and the stated range covers the measured number.
By their numbers in this assay, from the lowest: compound 1; then compounds 3 and 2 (each within the scatter of the next).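

In this assay, putting 2-nitrophenyl in place of 4-chlorophenyl on a carbon with a double bond to nitrogen gives a 1.0-fold lower number from compound 2 to compound 3 (0.00 log units; within the scatter), so the two imines cannot be told apart on this read-out. The earlier step showed only that building an aryl imine onto the amino nitrogen of the shared core moved the number modestly upward, whereas this pair keeps the imine and varies the aryl group alone; here, two aryl groups with different substituents stand in for each other without a difference that exceeds the usual scatter. No supporting measurement is available to explain why these two aryl groups give such similar numbers.

Going by these compounds, what remains open is whether this tolerance extends beyond these two aryl groups, since one pair cannot establish a rule for the whole position. An amine or a carboxylic acid on the phenyl ring, or a butyl chain in place of the ring on the same imine carbon, could either leave the number within the scatter or move it clearly away from those of the two imines.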